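One double bond, two configurations, one open question

A few compounds are considered here, and "the series" means these few. Any claim that something is new, unique, unknown or untested is made for them only; others in the source may bear on it.

Compound 1 `C/C(=N/NC(=S)Nc1ccccc1)c1ccccn1` gives 0.18 nM
Compound 2 `C/C(=N\NC(=S)Nc1ccccc1Cl)c1ccccn1` gives 0.16 nM

In a functional assay on MCF7 cells (Homo sapiens) for cytotoxicity, read by MTT assay, with a stated time of 48 h (on this read-out higher numbers stand for weaker inhibition and lower numbers for stronger inhibition), compound 2 gives 0.16 nM and compound 1 gives 0.18 nM as its value, so the two lie within the usual scatter of repeated measurements. Compound 3 `C/C(=N/NC(=S)Nc1ccccc1Cl)c1ccccn1` has not yet been measured. Set against compound 2, it shows the two compounds have the same atoms and bonds and differ only in configuration as drawn: 1 of 1 stereo elements differ; a double bond is drawn E in compound 2 and Z in compound 3 and nothing else: a double bond is drawn E in compound 2 and Z in compound 3. For the measured compounds named here, no measured pair here shows what such a change does, so any expectation rests on thin ground. Going by the values given here, the only guide is how closely the two measured values agree. The expected 1.1-fold higher number from compound 2 to compound 3 (0.03 log units; within the scatter) in this assay stays within the scatter, with neither direction favoured. For compound 3 the estimate of 0.17 nM comes with an expected range from 0.07 nM to 0.45 nM around it.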

Compound 3, half-maximal inhibitory concentration: 0.16 nM
The estimate for compound 3 lay 1.1-fold (0.03 log units) above the measured number; measured number inside the range.
By their numbers in this assay, from the lowest: compounds 2, 3 and 1 (each within the scatter of the next).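

In this assay, the double bond's drawn configuration is all that separates one pair, so that pair tests this single feature: the fact that compounds 2 and 3 differ only in the configuration as drawn. Reversing that configuration gives no change at the digits printed from compound 2 to compound 3 (within the scatter), so this pair shows no difference that the read-out can separate from scatter. For the compounds shown here, with the double bond now drawn the same way, chloro in place of hydrogen on an aromatic carbon gives a 1.1-fold lower number from compound 1 to compound 3 (0.05 log units; within the scatter), a clean comparison of that one change that the earlier compounds, which differed in both features, could not offer.

The compounds shown leave open whether a different group on that aromatic carbon, such as a methoxy group or an amine, would move the number beyond the scatter. They also leave open whether the double bond's configuration matters when the chloro group is absent.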